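Arylimino thiazolidinone series: aryl swap on the imine nitrogen

A few compounds are considered here, and "the series" means these few. Any claim that something is new, unique, unknown or untested is made for them only; others in the source may bear on it.

Measured so far:
compound 1 `COc1ccc(/C=C2/CN(C)/C(=N/c3ccc(Cl)cc3)S2)cc1` with 7600 nM
compound 2 `COc1ccc(/C=C2\S/C(=N\c3ccc(Cl)cc3)N(C)C2=O)cc1` with 39300 nM
compound 3 `COc1ccc(/C=C2\S/C(=N\c3cc(C(F)(F)F)cc(C(F)(F)F)c3)N(C)C2=O)cc1` with 77800 nM

All three values come from a functional assay on MCF7 cells (Homo sapiens) for antiproliferative activity, read by MTT assay, with a stated time of 72 h; on this read-out higher numbers stand for weaker inhibition and lower numbers for stronger inhibition. Compound 2 sits second highest of the three numbers. Its nearest neighbour is compound 3, whose 77800 nM lies within the usual scatter of the value of compound 2, so no order between these two can be stated. Its furthest neighbour is compound 1, whose 7600 nM stands beyond the scatter and lower than the value of compound 2; compound 1 also carries a different core, so this gap cannot be tied to the aryl group alone.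

Compound 4 `COc1ccc(/C=C2\S/C(=N\c3c(C)cccc3C)N(C)C2=O)cc1` is not yet measured. Relative to compound 2 it carries 2,6-dimethylphenyl in place of 4-chlorophenyl on a double-bonded nitrogen. Going by the values given here, no measured pair in the set isolates this kind of aryl exchange. Among the compounds with values here, the only comparison on the shared core, compound 2 against compound 3, shows a difference within the scatter, which gives no ground to expect a step beyond the scatter in either direction for compound 4.

Compound 4 is therefore expected near the value of compound 2, at an estimated 48000 nM with a range of 15000 nM to 150000 nM. The step this estimate means, a 1.2-fold higher number from compound 2 to compound 4 (0.09 log units; within the scatter), is expected to lie within the scatter.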

Compound 4, half-maximal inhibitory concentration: > 100000 nM
Compound 4: no number, only a limit; the forecaster's own chance of this, stated with the estimate: 20%; middle value at least 2.0-fold (0.31 log units) away from the limit.
By their numbers in this assay, from the lowest: compound 1; then compounds 2 and 3 (each within the scatter of the next). At a limit, above all of these: compound 4.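

In this assay compound 4 reads > 100000 nM, which is a limit of the assay and not a number. Placing 2,6-dimethylphenyl in place of 4-chlorophenyl on a double-bonded nitrogen gives an at least 2.5-fold higher number from compound 2 to compound 4 (0.40 log units; beyond the scatter), the first step beyond the scatter for an aryl exchange at this position on the shared core, where the values of compound 2 and compound 3 had stayed within the scatter of each other. The aryl group on this nitrogen is therefore not indifferent to the read-out, although only a lower bound on the size of this step can be read: the limit of > 100000 nM in this assay, at which 1 of the 4 values shown sits.

As far as these compounds go, it remains open whether the step follows from the gain of the two methyl groups or from the loss of the chlorine, and an aryl group carrying a single methyl, an amine or a carboxylic acid at this nitrogen would help to separate these readings. From the compounds shown here alone, it is also open whether the same exchange on the core of compound 1 would give a step of similar size.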